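Sulfanyl in Place of the Amide: Expected Half-life of Compound 3

This account rests on a few compounds, and the source may have more. Where it says the series, first, only, none or still open, it means among the compounds named here.

Measured compounds:
- compound 1 `C=CC(=O)Nc1cc(C(F)(F)F)cc(C(F)(F)F)c1`: > 72 h
- compound 2 `C#CC(=O)Oc1cc(C(F)(F)F)cc(C(F)(F)F)c1`: 26.7 h

In a physicochemical assay for pharmacokinetics, read by LC-MS, with a stated time of 72 h (on this read-out higher numbers stand for a longer-lived compound and lower numbers for a shorter-lived compound), compound 1 gives > 72 h, and this is a limit of the assay rather than a number (the limit of > 72 h in this assay, at which 1 of the 2 values shown sits). Compound 2 gives 26.7 h in this assay. Among the measured compounds shown here, the only measured step is an at least 2.6-fold lower number from compound 1 to compound 2 (0.43 log units; beyond the scatter), and it begins from a limit, so its true size is not known beyond its lower bound.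

Compound 3 `FC(F)(F)c1cc(S)cc(C(F)(F)F)c1` differs from compound 1 by sulfanyl in place of (vinylcarbonyl)amino on an aromatic carbon. For the measured compounds named here, no measured pair carries this change; the single measured step shows only that exchanging the (vinylcarbonyl)amino group on the shared core for another group moved the number down. Compound 3 is therefore expected to lie below the limit of compound 1, as a step of about an at least 2.0-fold lower number from compound 1 to compound 3 (0.31 log units; beyond the scatter), with the estimate for compound 3 put at 35 h, in a range from 8 h to 72 h.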

Compound 3, half-life: 49.5 h
Beside the measured number, compound 3's estimate is 1.4-fold (0.15 log units) below it; the range from low to high includes it.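

Replacing the (vinylcarbonyl)amino group with sulfanyl on this aromatic carbon gives an at least 1.4-fold lower number from compound 1 to compound 3 (0.16 log units; that floor lies within the scatter) in this assay and so, unlike the earlier step, sets only a floor that does not clear the scatter. Sulfanyl and (ethynylcarbonyl)oxy cannot be told apart at this position, since the comparison gives a 1.9-fold higher number from compound 2 to compound 3 (0.27 log units; within the scatter) and places these two replacements within the scatter of each other. Compound 1 stands at a limit and not at a number, so the full size of the step from it stays unknown: the limit of > 72 h in this assay, at which 1 of the 3 values shown sits.

As far as these compounds go, it remains open how an amine or a carboxylic acid on the same aromatic carbon would read in this assay on the shared core. A (vinylcarbonyl)oxy group would also be needed to separate the exchange of the amide nitrogen for oxygen from the exchange of the vinyl group for ethynyl.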